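Chloro in Place of Fluoro: Expecting Compound 4

The source may report more compounds than this note shows. Statements on the series, on what has been measured and on what is new or still open speak of the compounds shown alone.

Of the compounds shown here, three sharing one core have been tested in an assay for positive allosteric modulation of metabotropic glutamate receptor 3 (Rattus norvegicus); a higher number here means that more compound is needed for the effect, a lower number that less compound is needed. Compound 1 `COc1ccc(C(=O)O)cc1O[C@H](C)COc1ccc(C(=O)CC(C)(C)C)c(O)c1C` gives 1850 nM. Compound 2 `Cc1c(OC[C@H](C)COc2ccc(F)c(C(=O)O)c2)ccc(C(=O)CC(C)(C)C)c1O` gives 651 nM in this assay, and compound 3 `Cc1c(OC[C@@H](C)COc2ccc(F)c(C(=O)O)c2)ccc(C(=O)CC(C)(C)C)c1O` gives 1180 nM. Compound 3 stands second highest of the three numbers, and its value lies within the usual scatter of both the value of compound 1 and the value of compound 2. For the measured compounds named here, the only measured step between compounds differing in a single place is a 1.8-fold higher number from compound 2 to compound 3 (0.26 log units; within the scatter); because of the fact that compounds 2 and 3 differ only in the configuration as drawn, that step shows only that the drawn configuration at the saturated chain carbon gives no change that rises above the scatter.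

Compound 4 `Cc1c(OC[C@@H](C)COc2ccc(Cl)c(C(=O)O)c2)ccc(C(=O)CC(C)(C)C)c1O` has not yet been measured. Relative to compound 3 it carries chloro in place of fluoro on an aromatic carbon. Going by the values given here, no measured step involves an exchange of one halogen for another. The measured compounds give no indication of how this exchange moves the number. The expectation is a step of no size beyond the scatter, a 1.2-fold lower number from compound 3 to compound 4 (0.07 log units; within the scatter). Compound 4 is expected to give 1000 nM in this assay, within a range from 400 nM to 2500 nM.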

Compound 4, half-maximal effective concentration: 2200 nM
For compound 4 the middle estimate is 2.2-fold (0.34 log units) below the measured one; low and high end bracket the measured number.
By their numbers in this assay, from the lowest: compounds 2, 3, 1 and 4 (each within the scatter of the next, the first and the last beyond it).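

In this assay, putting chloro in place of fluoro on the aromatic carbon ortho to the carboxy group gives a 1.9-fold higher number from compound 3 to compound 4 (0.27 log units; within the scatter). For the compounds shown here, this is the first look at an exchange of one halogen for another in this set, and it shows that, with the configuration drawn in compound 3, this position can carry either fluoro or chloro without a step that rises above the scatter. Going by these compounds alone, the earlier compounds could not show this, since the one step among them concerned only the drawn configuration at a saturated chain carbon, and nothing measured here says why the number responds to the halogen exchange as it does.

The compounds shown leave open whether a bromo, a methyl or a methoxy group at this position, or a plain hydrogen in place of the halogen, would produce a step beyond the scatter. They also leave open whether the same exchange of fluoro for chloro would read the same way with the configuration drawn in compound 2, and whether it would still do so with a tetrazole in place of the carboxy group.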